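Sulfonyl Replaces Benzyl on the Ring Nitrogen

A few compounds are considered here, and "the series" means these few. Any claim that something is new, unique, unknown or untested is made for them only; others in the source may bear on it.

Compound 1 has the structure `COc1ccc(-c2cc(=O)c3c(OC)cc(OC)cc3n2Cc2ccccc2)cc1`. In a functional assay on HepG2 cells (Homo sapiens) for antiproliferative activity, with a stated time of 72 h (on this read-out lower numbers stand for an effect already at smaller amounts and higher numbers for an effect only at larger amounts of compound), compound 1 gives > 17300 nM, which is a limit of the assay rather than a number. Compound 2 has the structure `COc1ccc(-c2cc(=O)c3c(OC)cc(OC)cc3n2S(=O)(=O)c2cccc(Br)c2)cc1`. In this assay compound 2 gives > 58600 nM, again a limit rather than a number. One measured step connects these two: a step that the two limits leave unreadable from compound 1 to compound 2; the two limits, the limit of > 17300 nM in this assay, at which 1 of the 2 values shown sits, and (the limit of > 58600 nM in this assay, at which 1 of the 2 values shown sits), leave its size open. Compound 3 has the structure `COc1ccc(-c2cc(=O)c3c(OC)cc(OC)cc3n2S(=O)(=O)c2ccc(C)cc2)cc1` and is not yet measured. The change from compound 1 to compound 3 is (4-methylphenyl)sulfonyl in place of benzyl on an aromatic nitrogen. For the measured compounds named here, the only measured step that resembles it is the one from compound 1 to compound 2, where a sulfonyl group likewise enters on the aromatic nitrogen in place of benzyl, and that step could not be read. Nothing here points to a gain: both compounds with a known value sit at a limit. For compound 3 the expectation is therefore again a result at or beyond the limit, with a step that the limit leaves unreadable from compound 1 to compound 3 that is not expected to show a clear gain. The estimate for compound 3 in this assay is 50000 nM, within 15000 nM to 200000 nM.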

Compound 3, half-maximal effective concentration: > 44800 nM
Compound 3: only a limit was reported; the forecaster's own chance of this, stated with the estimate: 85%; the middle value lies beyond the limit too.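

In this assay compound 3 gives > 44800 nM, which is a limit and not a number. For the compounds shown here, compound 1 and compound 2 also stand only at limits, so no step among compound 1, compound 2 and compound 3 can be read. The compounds shown leave open how benzyl, (3-bromophenyl)sulfonyl and (4-methylphenyl)sulfonyl on the aromatic nitrogen truly compare.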